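A few compounds are considered here, and "the series" means these few. Any claim that something is new, unique, unknown or untested is made for them only; others in the source may bear on it.

Three compounds share one core in the series described here. Compound 1 `Cc1ccc(CSc2nc3nc(C)cc(Nc4cc(-c5ccccc5)[nH]n4)n3n2)cc1`, compound 2 `COc1ccc(CSc2nc3nc(C)cc(Nc4cc(-c5ccccc5)[nH]n4)n3n2)cc1` and compound 3 `COc1ccc(Cn2ccc(Nc3cc(C)nc4nc(SCc5ccc(Br)cc5)nn34)n2)cc1` were all tested in a functional assay on MGC-803 cells (Homo sapiens) for inhibition, read by MTT assay, with a stated time of 72 h; on this read-out lower numbers stand for stronger inhibition and higher numbers for weaker inhibition. Compound 2 gives 3170 nM, and compound 1 gives 6960 nM, so that the change methyl in place of methoxy on an aromatic carbon produced a 2.2-fold higher number from compound 2 to compound 1 (0.34 log units; beyond the scatter). Compound 3 gives 12600 nM; how its core differs from that of compound 2 is not broken down here. Compound 4 `Cc1ccc(Cn2ccc(Nc3cc(C)nc4nc(SCc5ccc(Br)cc5)nn34)n2)cc1` carries the same change relative to compound 3, namely (methyl in place of methoxy on an aromatic carbon), in the same place. Because the earlier step of a 2.2-fold higher number from compound 2 to compound 1 (0.34 log units; beyond the scatter) was modest, a similar step is expected from compound 3 to compound 4, a 1.7-fold higher number from compound 3 to compound 4 (0.24 log units; within the scatter), though it rests on a single precedent. The estimate for compound 4 in this assay is therefore 22000 nM, within a range from 9000 nM to 55000 nM.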

Compound 4, half-maximal inhibitory concentration: 7420 nM
For compound 4 the middle estimate is 3.0-fold (0.47 log units) above the measured one; measured number outside the range, below it.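

Replacing methoxy with methyl on the core of compound 3 gave a 1.7-fold lower number from compound 3 to compound 4 (0.23 log units; within the scatter) in this assay. The change therefore did not carry over unchanged from one core to the other: the same change on two cores in this assay, a 2.2-fold higher number (0.34 log units; beyond the scatter) from compound 2 to compound 1 and a 1.7-fold lower number (0.23 log units; within the scatter) from compound 3 to compound 4, 3.7-fold (0.57 log units) apart, beyond the scatter of two such steps. This shows that the outcome of this change cannot be assumed to transfer between these two cores, but two pairs do not show which difference between the cores is responsible, nor how the change would read on any further core.

The compounds shown leave open how a hydroxyl, an amine or a carboxylic acid in place of the methoxy would read on each of the two cores. They also leave open whether either of those groups would differ between the cores as methyl does.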